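Bromo replaced by chloro in a growth-inhibition series

The compounds below may be only part of what the source reports. "The series", "measured", "known", "first", "only" and "open" are said of these compounds alone.

Measured compounds:
compound 1 `COc1cc(C2CC(c3ccc(Br)cc3)=NN2C(C)=O)ccc1OCc1cn(Cc2ccc([N+](=O)[O-])cc2)nn1` — 23%
compound 2 `COc1ccc(C2CC(c3ccc(OCc4cn(Cc5ccc([N+](=O)[O-])cc5)nn4)cc3)=NN2C(C)=O)cc1OC` — 9%

Two compounds have been run in a functional assay on THP-1 cells (Homo sapiens) for inhibition, read by sulforhodamine B assay, tested at 100 uM; a lower number here means less inhibition of growth, a higher number more inhibition of growth at the concentration tested. Compound 1 gives the higher of the two numbers; compound 2 sits lower by a gap beyond the usual scatter. The two differ in more than one place, so their values say only that much.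

Compound 3 `COc1cc(C2CC(c3ccc(Cl)cc3)=NN2C(C)=O)ccc1OCc1cn(Cc2ccc([N+](=O)[O-])cc2)nn1` departs from compound 1 by a single exchange: chloro in place of bromo on an aromatic carbon. Within the data shown here, no measured pair shows this exchange, so its size is not anchored. A halogen-for-halogen swap of this kind is expected to move this assay little, if at all, with no step beyond the scatter in either direction; a slight drop is the more likely side.

The estimate for compound 3 is therefore 20%, within 8% to 34%, with the expected step of a number 3 percentage points lower from compound 1 to compound 3 (within the scatter).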

Compound 3, percent growth inhibition at one concentration: 37%
For compound 3 the middle estimate is 17 percentage points below the measured one; measured number above the stated range.
By their numbers in this assay, from the lowest: compound 2; then compound 1; then compound 3.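

The 4-bromophenyl position is sensitive to the identity of the halogen: in this assay, chloro in place of bromo on the aromatic carbon gives a change of a number 14 percentage points higher from compound 1 to compound 3 (beyond the scatter). The exchange alters one heavy atom and leaves the counts of rings, hydrogen-bond donors, hydrogen-bond acceptors and net charge unchanged, yet that alone is enough to shift the read-out on the core of compound 1. No data at hand bear on the origin of this step.

Still open, from the compounds shown here alone, is whether fluoro, methyl or an amine on the same aromatic carbon would give a number nearer compound 1 or compound 3. A single pair also leaves open whether the same exchange would give a similar step on a different core.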